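From a ring-bearing group to a smaller one on compound 2

The compounds below may be only part of what the source reports. "The series", "measured", "known", "first", "only" and "open" are said of these compounds alone.

Of the compounds shown here, two sharing one core have been measured. In an assay on DDT1 cells (Cricetulus griseus) for binding affinity to adenosine receptor A1 (Homo sapiens), read by radioligand binding (a lower number here means a stronger inhibitor, a higher number a weaker inhibitor), compound 1 `O=C(NC1CCC1)OC[C@H]1OC(n2cnc3c(NC4CCOC4)ncnc32)[C@H](O)[C@@H]1O` gives 306 nM, while compound 2 `O[C@@H]1[C@@H](CO/C(S)=N/C2CCC2)OC(n2cnc3c(NC4CCOC4)ncnc32)[C@@H]1O` gives 148 nM, the lowest of the two numbers. Going by the values given here, the only measured step, a 2.1-fold lower number from compound 1 to compound 2 (0.32 log units; beyond the scatter), exchanged an oxygen for a sulfur. Compound 3 `CN(C)C(=S)OC[C@H]1OC(n2cnc3c(NC4CCOC4)ncnc32)[C@H](O)[C@@H]1O` differs from compound 2 in a different way: a group of 5 heavy atoms (3 carbon, 1 nitrogen, 1 sulfur; no ring) in place of a group of 7 heavy atoms (5 carbon, 1 nitrogen, 1 sulfur; one four-membered non-aromatic ring of carbon only), on an oxygen on a saturated carbon. Among the compounds with values here, no measured step covers such an exchange, so little guidance exists; the estimated step of a 1.7-fold higher number from compound 2 to compound 3 (0.23 log units; within the scatter) is expected to be small, at most a slight weakening. For compound 3 the expected value is 250 nM, within a range from 90 nM to 700 nM.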

Compound 3, inhibition constant: 205 nM
Compound 3: middle estimate off by 1.2-fold (0.09 log units), on the high side, and the stated range covers the measured number.
By their numbers in this assay, from the lowest: compounds 2, 3 and 1 (each within the scatter of the next, the first and the last beyond it).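

In this assay the group on this oxygen can lose both its four-membered ring and its hydrogen-bond donor with little consequence: the ring-free group gives a 1.4-fold higher number from compound 2 to compound 3 (0.14 log units; within the scatter) and also a 1.5-fold lower number from compound 1 to compound 3 (0.17 log units; within the scatter) in the second pair. So at this position, neither step separates compound 3 from its neighbour beyond the scatter. No evidence is available to explain these steps.

The ring and the donor left in a single change, so neither can be judged alone. As far as these compounds go, how a carboxylic acid or a longer chain would behave at this position also remains open.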